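Phenyl for hydrogen on a biphenylmethylene lactone

This account rests on a few compounds, and the source may have more. Where it says the series, first, only, none or still open, it means among the compounds named here.

Measured compounds:
Compound 1, `CCCCCCCCC/C=C1/CC(CO)(COC(=O)c2ccc(-c3ccccc3)cc2)OC1=O`, gives 6.61 in a physicochemical assay for lipophilicity; on this read-out higher numbers stand for higher lipophilicity and lower numbers for lower lipophilicity.
Compound 2, `O=C1OC(CO)(COC(=O)c2ccccc2)C/C1=C/c1ccc(-c2ccccc2)cc1`, gives 3.9 in this assay.

Compound 2 stands at the lower of the two numbers; the nearest value is that of compound 1, which lies higher by a gap that is beyond the usual scatter. The two structures differ in more than one place, so their two values are all that can be said of that pair.

Compound 3, `O=C1OC(CO)(COC(=O)c2ccc(-c3ccccc3)cc2)C/C1=C/c1ccc(-c2ccccc2)cc1`, has not been measured in this assay. It differs from compound 2 in a single place: phenyl in place of hydrogen on an aromatic carbon. Within the data shown here, no measured pair in this set carries exactly this change, so the size of the step rests on the change itself and on where compound 2 sits. An upward step of fair size is expected from compound 2 to compound 3, well beyond the scatter, since the two values of compound 1 and compound 2 show how wide the spread in this set already is. For compound 3 the estimated value is 5.7, with a range from 5.1 to 6.3, which means an expected step of a number 1.80 log units higher from compound 2 to compound 3 (beyond the scatter).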

Compound 3, partition coefficient: 5.66
Compound 3: the middle estimate sits 0.04 log units above what was measured, within the range that was stated.
By their numbers in this assay, from the lowest: compound 2; then compound 3; then compound 1.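

Compound 3 gives this set its first reading of a single change at this place: phenyl in place of hydrogen on an aromatic carbon, para to a large group, the change that turns phenyl into 4-phenylphenyl, moves this assay by a number 1.76 log units higher from compound 2 to compound 3 (beyond the scatter). Among these compounds, it also gives the first one-place reading at the other end of the molecule, where 4-phenylphenyl in place of nonyl on a double-bonded chain carbon bound to a double-bonded ring carbon gives a modest step of a number 0.95 log units lower from compound 1 to compound 3 (beyond the scatter), also beyond the scatter but opposite in direction. Nothing measured in this set accounts for the size of either step.

With only phenyl seen at this place, the compounds leave open how far a methoxy group, an amine or a carboxylic acid on the same aromatic carbon would shift the value. They also leave open where a chain shorter or longer than nonyl would fall, and whether the step seen with phenyl would keep its size in a compound carrying nonyl at the other end.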